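From 4-Methylphenyl to 2,5-Dimethylphenyl on the Sulfonyl Sulfur

The source may hold more compounds than are shown below. What is called first, only, known or untested is meant among the compounds shown, and "the series" means these compounds.

In an ADME assay on HEK-293T cells (Homo sapiens) for cytotoxicity, read by MTT assay, with a stated time of 24 h (on this read-out higher numbers stand for lower toxicity in this test and lower numbers for higher toxicity in this test), compound 1 `Cc1ccc(-c2nn(-c3ccccc3)cc2-c2nc3ccccc3[nH]2)cc1` gives 187000 nM. Among the measured compounds shown here, compound 2 `Cc1ccc(-c2nn(-c3ccccc3)cc2-c2nc3ccccc3n2S(=O)(=O)c2ccc(C)cc2)cc1` gives 79300 nM, the lower of the two numbers measured so far. Compound 3 `Cc1ccc(-c2nn(-c3ccccc3)cc2-c2nc3ccccc3n2S(=O)(=O)c2cc(C)ccc2C)cc1` differs from compound 2 in one place, with 2,5-dimethylphenyl in place of 4-methylphenyl on a sulfonyl sulfur. For the measured compounds named here, the only measured step that bears on this is a 2.4-fold lower number from compound 1 to compound 2 (0.37 log units; beyond the scatter), a modest one that came with (4-methylphenyl)sulfonyl in place of hydrogen on an aromatic nitrogen. Going by the values given here, that step added the whole sulfonyl group, whereas compound 3 keeps it and exchanges only the group on the sulfur, and no measured step covers such an exchange. In this assay, the expected change is therefore none beyond the scatter, an estimated 1.1-fold lower number from compound 2 to compound 3 (0.02 log units; within the scatter). For compound 3 the estimated value is 75000 nM, with an expected range of 40000 nM to 140000 nM.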

Compound 3, half-maximal cytotoxic concentration: 82200 nM
The estimate for compound 3 lay 1.1-fold (0.04 log units) below the measured number, and the stated range covers the measured number.
By their numbers in this assay, from the lowest: compounds 2 and 3 (each within the scatter of the next); then compound 1.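

In this assay, 2,5-dimethylphenyl in place of 4-methylphenyl on the sulfonyl sulfur gives a 1.0-fold higher number from compound 2 to compound 3 (0.02 log units; within the scatter), so this exchange on the aryl group leaves the number within the scatter. Set against the hydrogen on the aromatic nitrogen of compound 1, the new sulfonyl group gives a 2.3-fold lower number from compound 1 to compound 3 (0.36 log units; beyond the scatter), and the earlier sulfonyl group gave a 2.4-fold lower number from compound 1 to compound 2 (0.37 log units; beyond the scatter), so the lower number now holds for two aryl groups on the sulfur rather than one. Nothing available explains either result.

Still open, as far as these compounds go, is whether the number would hold with something other than a methyl-bearing phenyl on the sulfur, such as a short alkyl chain or a phenyl carrying an amine or a carboxylic acid. Also open, from the compounds shown here alone, is whether a carbonyl in place of the sulfonyl would give a similar number.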